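Estimating Paw Edema Inhibition After a Butyl-to-Hydroxyethyl Swap

The source may report more compounds than this note shows. Statements on the series, on what has been measured and on what is new or still open speak of the compounds shown alone.

Measured so far:
compound 1, `CCCN1N=C2/C(=C/c3ccccc3)CN(C)CC2C1c1ccccc1`, 47%
compound 2, `CCCCN1N=C2/C(=C/c3ccccc3)CN(C)CC2C1c1ccccc1`, 26%

In a functional assay on the whole organism (strain Sprague-Dawley) for inhibition, with Rattus norvegicus as the target, read by paw edema, with a stated time of 3 h, at a dose of 150 mg/kg by the oral route (on this read-out lower numbers stand for less inhibition and higher numbers for more inhibition at the one dose given (going by the name of the read-out)), compound 1 gives 47%, while compound 2 gives 26%. Among the measured compounds shown here, compound 2 therefore stands lowest of the two measured numbers; the only measured step, a number 21 percentage points lower from compound 1 to compound 2 (beyond the scatter), came from methyl in place of hydrogen on a saturated chain carbon, three bonds along the chain from an amine nitrogen in a ring.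

Compound 3, `CN1C/C(=C\c2ccccc2)C2=NN(CCO)C(c3ccccc3)C2C1`, is not yet measured. It differs from compound 2 in one place: hydroxy in place of ethyl on a saturated chain carbon, two bonds along the chain from an amine nitrogen in a ring. Cut one bond further out, the change reads butyl to 2-hydroxyethyl. For the measured compounds named here, no measured step covers a hydroxy group, so the expectation rests only on the chain length: lengthening the chain gave the drop a number 21 percentage points lower from compound 1 to compound 2 (beyond the scatter), and shortening it again is expected to regain some inhibition for compound 3, a step of a number 14 percentage points higher from compound 2 to compound 3 (beyond the scatter) upward. The estimate for compound 3 is 40%, ranging from 20% to 60%.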

Compound 3, a percentage reported as inhibition, in the whole organism at one dose (the size of the read-out at that dose, not a potency): 41%
Compound 3: middle estimate off by 1 percentage points, on the low side; the range from low to high includes it.
By their numbers in this assay, from the lowest: compound 2; then compounds 3 and 1 (each within the scatter of the next).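

Two bonds along the chain from an amine nitrogen in a ring, hydroxy in place of ethyl gives a number 15 percentage points higher from compound 2 to compound 3 (beyond the scatter) in this assay and so turns butyl into 2-hydroxyethyl. Among the compounds shown here, the earlier compounds carried only plain carbon chains, so this is the first sign that a hydroxy group can sit on this chain without a loss of inhibition. Against the propyl chain, hydroxy in place of methyl gives a number 6 percentage points lower from compound 1 to compound 3 (within the scatter) and so 2-hydroxyethyl and propyl cannot be told apart in this read-out.

Nothing available here bears on what lies behind these numbers. As far as these compounds go, it also remains open whether an amine or a carboxylic acid at the end of this chain, or a hydroxy group on a longer chain, would keep the reading of compound 3 in this assay at this single dose.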